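Methylation at selenium: notes on compound 3 to compound 4

A few compounds are considered here, and "the series" means these few. Any claim that something is new, unique, unknown or untested is made for them only; others in the source may bear on it.

Compound 3 `[SeH]c1nc(NCc2ccccc2)c2ccccc2n1` carries a hydrogen on its selenium. In an ADME assay on BEAS-2B cells (Homo sapiens) for cytotoxicity, read by MTT assay, with a stated time of 72 h (a higher number here means a weaker inhibitor of growth, a lower number a stronger inhibitor of growth), compound 3 gives > 100000 nM, which is a limit of the assay and not a number. The sulfur counterpart, compound 2 `Sc1nc(NCc2ccccc2)c2ccccc2n1`, gives > 100000 nM in this assay, again a limit. Compound 1 `COc1ccc(CNc2nc([Se]C)nc3ccccc23)cc1`, which already bears a methyl on its selenium, gives > 100000 nM in this assay, also a limit. Among the compounds with values here, the only measured step between neighbours, a step that the two limits leave unreadable from compound 2 to compound 3, cannot be read in size because both of its ends sit at the limit of > 100000 nM in this assay, at which 3 of the 3 values shown sit. No measured value in this series stands anywhere other than that limit.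

Compound 4 `C[Se]c1nc(NCc2ccccc2)c2ccccc2n1` differs from compound 3 by methyl in place of hydrogen on a selenium. Within the data shown here, no step bears directly on this change; the only guide is compound 1, whose methyl on selenium gives > 100000 nM in this assay. The step that the limit leaves unreadable from compound 3 to compound 4 is therefore expected to lie within the scatter, with compound 4 most likely returning only a limit again. Compound 4 is estimated at 150000 nM, in the range 70000 nM to 400000 nM.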

Compound 4, concentration for total growth inhibition: 37000 nM
For compound 4 the middle estimate is 4.1-fold (0.61 log units) above the measured one; the measured number lies below the stated range.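

In this assay, methyl in place of hydrogen on a selenium gives an at least 2.7-fold lower number from compound 3 to compound 4 (0.43 log units; beyond the scatter), so growth inhibition at this position responds to the change, and compound 4 is the only compound shown with a value that is a number and not a limit. The same compound also separates from its sulfur neighbour, with an at least 2.7-fold lower number from compound 2 to compound 4 (0.43 log units; beyond the scatter), and hydrogen in place of methoxy on an aromatic carbon gives an at least 2.7-fold lower number from compound 1 to compound 4 (0.43 log units; beyond the scatter), so a methyl on selenium does not by itself bring a value under the limit. All three steps give only a minimum size, as the other end of each is a limit: the limit of > 100000 nM in this assay, at which 3 of the 4 values shown sit.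

From the compounds shown here alone, what an ethyl group or a longer chain on the selenium would give stays open. So does the result for a methyl on the sulfur of compound 2, and with it how much of the step belongs to selenium.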